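Stearoyl amides: morpholine in place of pyrrolidine

The source may hold more compounds than are shown below. What is called first, only, known or untested is meant among the compounds shown, and "the series" means these compounds.

The study measures growth inhibition in a functional assay on U-251 cells (Homo sapiens) for antiproliferative activity, read by sulforhodamine B assay, with a stated time of 48 h; a higher number here means a weaker inhibitor of growth, a lower number a stronger inhibitor of growth. Of the compounds shown here, two have numbers so far. Compound 1 `CCCCCC[C@@H](O)C/C=C\CCCCCCCC(=O)N1CCOCC1` gives 33.1 ug/mL in this assay. Compound 2 `CCCCCCCCCCCCCCCCCC(=O)N1CCCC1` gives 8 ug/mL in this assay, the lowest of the two numbers; compound 1 stands beyond the scatter above it. Going by the values given here, no single-point step between measured compounds is available, since compound 1 differs from compound 2 in more than one place.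

The next compound, compound 3 `CCCCCCCCCCCCCCCCCC(=O)N1CCOCC1`, departs from compound 2 by one change: morpholin-4-yl in place of pyrrolidin-1-yl on a carbonyl carbon. Compound 1 also carries a morpholin-4-yl group on its carbonyl carbon, but its chain differs from that of compound 2, so its higher number cannot be laid to the ring alone. The author therefore expects a modest step upward from compound 2 to compound 3, a 1.9-fold higher number from compound 2 to compound 3 (0.27 log units; within the scatter), in this assay, possibly no larger than the scatter, and estimates compound 3 at 15 ug/mL in this assay, within the range 6 ug/mL to 40 ug/mL.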

Compound 3, concentration for 50% growth inhibition: 39.9 ug/mL
Compound 3: the middle estimate sits 2.7-fold (0.42 log units) below what was measured, and the stated range covers the measured number.
By their numbers in this assay, from the lowest: compound 2; then compounds 1 and 3 (each within the scatter of the next).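

With the stearoyl chain held fixed, the ring on the carbonyl carbon is the only difference, and in this assay morpholin-4-yl in place of pyrrolidin-1-yl gives a 5.0-fold higher number from compound 2 to compound 3 (0.70 log units; beyond the scatter). Going by these compounds alone, this is the first reading of a single change at this position: compound 1 and compound 2 differ in both chain and ring, so that pair could not show that the ring alone moves the number beyond the scatter. The change replaces a five-membered ring with one hetero atom by a six-membered ring with two hetero atoms and adds one hydrogen-bond acceptor, but nothing measured here ties the step to any one of these differences.

The compounds shown leave open how other rings on the same carbonyl carbon would read, such as piperidin-1-yl, which keeps six ring members without the ring oxygen, or piperazin-1-yl, which has a second ring nitrogen in its place. They also leave open whether the same ring change would give a step of similar size on the hydroxy-bearing unsaturated chain of compound 1, a comparison that would need the pyrrolidin-1-yl amide of that chain.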